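A few compounds are considered here, and "the series" means these few. Any claim that something is new, unique, unknown or untested is made for them only; others in the source may bear on it.

Measured so far in an ADME assay on MT4 cells (Homo sapiens) for cytotoxicity, read by MTT assay, with a stated time of 4 days; on this read-out lower numbers stand for higher toxicity in this test and higher numbers for lower toxicity in this test:
compound 1 `N#Cc1ccc(Nc2nc(N)nc(Oc3cccc4ccccc34)n2)cc1` — 39100 nM
compound 2 `CCCNc1nc(Nc2ccc(C#N)cc2)nc(Oc2cccc3ccccc23)n1` — 29500 nM
compound 3 `N#Cc1ccc(Nc2nc(N)nc(Oc3ccc4ccccc4c3Br)n2)cc1` — 133000 nM

Compound 3 stands highest of the three; the difference between its core and the core of compound 1 is not broken down here.

Compound 4 `CCCNc1nc(Nc2ccc(C#N)cc2)nc(Oc2ccc3ccccc3c2Br)n1` is not yet measured. It is derived from compound 3 by propyl in place of hydrogen on a nitrogen on an aromatic ring. The same change is already seen once in the series, from compound 1 to compound 2, as propyl in place of hydrogen on a nitrogen on an aromatic ring; the place lines of both changes agree word for word, so it is the same change. That earlier step gave a 1.3-fold lower number from compound 1 to compound 2 (0.12 log units; within the scatter).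

For compound 4 the expected step is a 1.3-fold lower number from compound 3 to compound 4 (0.12 log units; within the scatter), resting on the earlier step of a 1.3-fold lower number from compound 1 to compound 2 (0.12 log units; within the scatter) having stayed within the scatter. Compound 4 is therefore estimated at 100000 nM in this assay, with the range 40000 nM to 250000 nM.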

Compound 4, half-maximal cytotoxic concentration: > 263000 nM
Compound 4 gave a limit, no number (the forecaster's own chance of this, stated with the estimate: 15%); at least 2.6-fold (0.41 log units) between middle value and limit.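

In this assay compound 4 gave only a limit, > 263000 nM, and not a number. Carrying propyl in place of hydrogen onto the core of compound 3 gives an at least 1.9-fold higher number from compound 3 to compound 4 (0.29 log units; that floor lies within the scatter), so this step is known only as a floor, and that floor lies within the scatter. Beside the earlier step, this neither confirms nor rules out that the change carries across the two cores: the same change on two cores in this assay, a 1.3-fold lower number (0.12 log units; within the scatter) from compound 1 to compound 2 and an at least 1.9-fold higher number (0.29 log units; that floor lies within the scatter) from compound 3 to compound 4; the limit leaves it open whether they differ.

From the compounds shown here alone, the size of the step on the core of compound 3 remains open, as does its direction relative to the earlier step. Also open, going by these compounds, is whether an ethyl group, a butyl group or a longer chain in the same place would behave alike on both cores.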